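This account rests on a few compounds, and the source may have more. Where it says the series, first, only, none or still open, it means among the compounds named here.

The measured compounds are:

compound 1, `Clc1ccccc1-c1nc2ncccc2o1`, giving 38% in a functional assay on the whole organism for inhibition, with Rattus norvegicus as the target, at a dose of 30 mg/kg; on this read-out higher numbers stand for more inhibition at the one dose given (going by the name of the read-out) and lower numbers for less inhibition;
compound 2, `N#Cc1cccc(-c2nc3ncccc3o2)c1`, giving 21% in this assay;
compound 3, `FC(F)(F)c1cccc(-c2nc3cccnc3o2)c1`, giving 7% in this assay.

Compound 3 stands lowest of the three numbers. Its nearest neighbour is compound 2, whose value lies above it by more than the scatter, and compound 1 lies furthest from it, again beyond the scatter. All three share the same core and differ only in the group carried on the pendant six-membered carbon ring, yet no two of them differ in one place alone, so no single step can be read directly from the measured values.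

Compound 4, `Cc1cccc(-c2nc3cccnc3o2)c1`, has not been measured in this assay. It differs from compound 3 in one place: methyl in place of trifluoromethyl on an aromatic carbon. For the measured compounds named here, with no measured pair to go by, the size of this change can only be guessed. Compound 3 sits low, and the other two compounds show that other groups on this ring can give higher values, so a moderate step upward from compound 3 is expected, one that may well remain within the scatter. The expected step is a number 8 percentage points higher from compound 3 to compound 4 (within the scatter). For compound 4 the estimate in this assay is 15%, with a range from 0% to 38%.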

Compound 4, a percentage reported as inhibition, in the whole organism at one dose (the size of the read-out at that dose, not a potency): 14%
For compound 4 the middle estimate is 1 percentage points above the measured one; low and high end bracket the measured number.
By their numbers in this assay, from the lowest: compounds 3, 4 and 2 (each within the scatter of the next, the first and the last beyond it); then compound 1.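

In this assay, for the compounds shown here, methyl in place of trifluoromethyl on an aromatic carbon, meta to a group of 9 heavy atoms, gives the first step that can be read between two measured compounds: a number 7 percentage points higher from compound 3 to compound 4 (within the scatter). At this place on the six-membered aromatic ring of carbon only, the two groups therefore cannot be told apart on this read-out, even though trifluoromethyl brings 4 heavy atoms and methyl brings 1, so this change in group size alone leaves the number within the usual scatter. No other measurement is at hand that could bear on this result.

Steps linking compound 1 or compound 2 to compound 3 or compound 4 cannot be read, as neither of the first two differs from either of the last two in one place alone. On these data alone, it remains open whether an amine, a carboxylic acid or a longer alkyl chain at this same place would give a number that stands clear of the scatter around compound 3 and compound 4, and whether the swap of trifluoromethyl for methyl would behave alike elsewhere on the ring.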